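Aryl ring change on a shared core, followed from compound 1

This account rests on a few compounds, and the source may have more. Where it says the series, first, only, none or still open, it means among the compounds named here.

Measured compounds:
compound 1 `COc1cc2c(Oc3ccc(NC(=O)c4nn(-c5ccccc5C)c(=O)cc4C)cc3F)ccnc2cc1OCCCN1CCCC1`, 760 nM
compound 2 `COc1cc2c(Oc3ccc(NC(=O)c4nn(-c5ccccc5C)c(=O)cc4C)cc3F)ccnc2cc1OCCCN1CCCCC1`, 1310 nM
compound 3 `COc1cc2c(Oc3ccc(NC(=O)c4nn(-c5ccccc5C)c(=O)cc4C)cc3F)ccnc2cc1OCCCN1CCC(C)CC1`, 1290 nM

In a functional assay on MKN-45 cells (Homo sapiens) for inhibition, read by MTT assay, with a stated time of 72 h (on this read-out higher numbers stand for weaker inhibition and lower numbers for stronger inhibition), compound 1 gives the lowest of the three numbers, yet the steps of a 1.7-fold higher number from compound 1 to compound 2 (0.24 log units; within the scatter) and a 1.7-fold higher number from compound 1 to compound 3 (0.23 log units; within the scatter) both stay within the scatter, as does a 1.0-fold lower number from compound 2 to compound 3 (0.01 log units; within the scatter), so no ordering among them is claimed. Compound 4 `COc1cc2c(Oc3ccc(NC(=O)c4nn(-c5ccccc5OC(F)(F)F)c(=O)cc4C)cc3F)ccnc2cc1OCCCN1CCCC1` differs from compound 1 by trifluoromethoxy in place of methyl on an aromatic carbon. Within the data shown here, none of the measured steps touches this part of the molecule; all three alter the ring at the end of the chain on the other side. There is therefore no shown step that bears on the change, and the expected step of a 1.1-fold higher number from compound 1 to compound 4 (0.02 log units; within the scatter) in this assay is judged to lie within the scatter. Compound 4 is estimated at 800 nM, between 300 nM and 2500 nM.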

Compound 4, half-maximal inhibitory concentration: 60 nM
The estimate for compound 4 lay 13-fold (1.12 log units) above the measured number; measured number below the stated range.
By their numbers in this assay, from the lowest: compound 4; then compounds 1, 3 and 2 (each within the scatter of the next).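

In this assay the change from 2-methylphenyl to 2-(trifluoromethoxy)phenyl gives a 13-fold lower number from compound 1 to compound 4 (1.10 log units; beyond the scatter), whereas the changes shown at the ring at the far end of the chain all stayed within the scatter. This aromatic carbon, ortho to a large group, is therefore a place where the substituent matters strongly. Nothing measured here accounts for the size of this step.

As far as these compounds go, whether methoxy, chlorine or trifluoromethyl on the same carbon would match trifluoromethoxy remains open. So does whether the step carries over to the piperidin-1-yl compound 2 and the 4-methylpiperidin-1-yl compound 3.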